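Benzothiepine series: quaternary ammonium to benzylamino at the aryl position

The compounds below may be only part of what the source reports. "The series", "measured", "known", "first", "only" and "open" are said of these compounds alone.

Measured so far:
- compound 1 `CCCC[C@]1(CC)CS(=O)(=O)c2ccc(Br)cc2[C@@H](c2cccc(OC)c2)[C@H]1O`: 70 nM in an assay on cells for inhibition of ileal sodium/bile acid cotransporter (Homo sapiens); on this read-out lower numbers stand for stronger inhibition and higher numbers for weaker inhibition
- compound 2 `CCCCC1(CCCC)CS(=O)(=O)c2ccc([N+](C)(C)C)cc2[C@@H](c2ccccc2)[C@H]1O`: 210 nM in this assay

Compound 2 gives the highest of the two numbers seen in this assay; compound 1 sits lower, and the gap between them lies beyond the usual scatter of repeated measurements. The two compounds differ in more than one place, so the comparison says only that much.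

Compound 3 `CCCCC1(CCCC)CS(=O)(=O)c2ccc(NCc3ccccc3)cc2[C@@H](c2ccccc2)[C@H]1O` keeps the core of compound 2 and changes one substituent: a group of 8 heavy atoms (7 carbon, 1 nitrogen; one six-membered aromatic ring of carbon only) in place of a group of 4 heavy atoms (3 carbon, 1 nitrogen; no ring), on an aromatic carbon. A charged group without a ring thus gives way to a neutral group carrying an aromatic ring and a hydrogen-bond donor and acceptor, at the same aromatic carbon of the fused system.

Among the compounds with values here, no measured pair tells the size of this kind of exchange. Within the data, compound 1 with a small neutral substituent at a comparable carbon gives 70 nM, below compound 2, so a modest move toward lower numbers is expected, though one that may not clear the scatter. In this assay the expected step is a 2.1-fold lower number from compound 2 to compound 3 (0.32 log units; beyond the scatter). Compound 3 is estimated at 100 nM, in the range 25 nM to 400 nM.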

Compound 3, half-maximal inhibitory concentration: 1900 nM
Compound 3: middle estimate off by 19-fold (1.28 log units), on the low side, and the stated range ends below it.
By their numbers in this assay, from the lowest: compound 1; then compound 2; then compound 3.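

In this assay, benzylamino on this aromatic carbon in place of the charged group without a ring gives a 9.0-fold higher number from compound 2 to compound 3 (0.96 log units; beyond the scatter), so at this position a larger neutral group with an aromatic ring and a hydrogen-bond donor is no substitute for the charged one. The rest of the structure stays the same across this pair, which shows that the read-out depends strongly on what this one carbon carries. Size, charge, ring and hydrogen-bonding counts all change together in this exchange, so the pair cannot show which of them carries the step, and no supporting data bear on it.

Open, as far as these compounds go, is where a dimethylamino group, with neither ring nor charge, or a benzyloxy group, with the ring but oxygen in place of nitrogen, would fall relative to these two compounds on this carbon. Also open, from the compounds shown here alone, is whether a quaternary ammonium group carrying a benzyl substituent, which would combine the charge with the ring, stays nearer the number of compound 2 or that of compound 3.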